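The compounds below may be only part of what the source reports. "The series", "measured", "known", "first", "only" and "open" are said of these compounds alone.

Compound 2 `N/C(=N\O)c1ccc(Nc2ccc(C3=C(S(=O)(=O)c4ccc(/C(N)=N/O)cc4)CC(c4ccccc4)(c4ccccc4)O3)cc2)cc1` gives 48900 nM in an ADME assay on THP-1 cells (Homo sapiens) for cytotoxicity, read by flow cytometry, with a stated time of 72 h; a lower number here means a stronger inhibitor, a higher number a weaker inhibitor. Among the three measured compounds it holds the second highest number: compound 3 `N/C(=N\O)c1ccc(S(=O)(=O)C2=C(c3ccc(Nc4ccccc4/C(N)=N/O)cc3)OC(c3ccccc3)(c3ccccc3)C2)cc1` gives 47800 nM, a value within the scatter of compound 2, and the step of a 1.0-fold lower number from compound 2 to compound 3 (0.01 log units; within the scatter) is not meaningful. Compound 1 `N/C(=N\O)c1ccc(C2=C(S(=O)(=O)c3ccc(/C(N)=N/O)cc3)CC(c3ccccc3)(c3ccccc3)O2)cc1` gives 119000 nM, and the step of a 2.4-fold lower number from compound 1 to compound 2 (0.39 log units; beyond the scatter) is modest. Compound 4 `N/C(=N\O)c1ccc(/C=C/c2ccc(Nc3ccc(C4=C(S(=O)(=O)c5ccc(/C(N)=N/O)cc5)CC(c5ccccc5)(c5ccccc5)O4)cc3)cc2)cc1` differs from compound 2 by a group of 12 heavy atoms (9 carbon, 2 nitrogen, 1 oxygen; one six-membered aromatic ring of carbon only) in place of a group of 4 heavy atoms (1 carbon, 2 nitrogen, 1 oxygen; no ring), on an aromatic carbon. The steps of a 2.4-fold lower number from compound 1 to compound 2 (0.39 log units; beyond the scatter) and a 2.5-fold lower number from compound 1 to compound 3 (0.40 log units; beyond the scatter) both show that enlarging this position from a group of 4 heavy atoms lowered the number modestly, so a further modest lowering, or no change beyond the scatter, is expected for compound 4. The estimated step of a 1.6-fold lower number from compound 2 to compound 4 (0.21 log units; within the scatter) gives compound 4 an expected value of 30000 nM, with a range from 12000 nM to 80000 nM.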

Compound 4, half-maximal inhibitory concentration: 41300 nM
For compound 4 the middle estimate is 1.4-fold (0.14 log units) below the measured one, within the range that was stated.
By their numbers in this assay, from the lowest: compounds 4, 3 and 2 (each within the scatter of the next); then compound 1.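

In this assay, the step of a 1.2-fold lower number from compound 2 to compound 4 (0.07 log units; within the scatter) lies within the scatter, so this larger group of 12 heavy atoms, with its added carbon ring, gives no readable change from the group of 4 heavy atoms. The earlier steps shown here from compound 1 showed a modest lowering on enlarging a group on an aromatic carbon, but here a further enlargement does not extend it. No measurement given here explains this result. The compounds shown leave open whether a carboxylic acid or an amine at this position would move the number beyond the scatter.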